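Benzyloxycarbonyl swap on the fluorophenyl pyrazole series

The source may hold more compounds than are shown below. What is called first, only, known or untested is meant among the compounds shown, and "the series" means these compounds.

Values in a functional assay on A549 cells (Homo sapiens) for antiproliferative activity, read by MTT assay, with a stated time of 48 h; on this read-out higher numbers stand for weaker inhibition and lower numbers for stronger inhibition:
- compound 1 `Fc1ccc(-c2nn(-c3ccccc3)cc2-c2nc3cc(F)ccc3[nH]2)cc1`: 1130 nM
- compound 2 `Cc1ccc2[nH]c(-c3cn(-c4ccccc4)nc3-c3ccc(F)cc3)nc2c1`: 1440 nM
- compound 3 `Fc1ccc(-c2nn(-c3ccccc3)cc2-c2nc3cc(C(F)(F)F)ccc3[nH]2)cc1`: 2340 nM

Compound 3 stands apart from only one of the other two. The steps are a 2.1-fold higher number from compound 1 to compound 3 (0.32 log units; beyond the scatter) and a 1.6-fold higher number from compound 2 to compound 3 (0.21 log units; within the scatter). The next change leads to compound 4 `O=C(OCc1ccccc1)c1ccc2[nH]c(-c3cn(-c4ccccc4)nc3-c3ccc(F)cc3)nc2c1` and is benzyloxycarbonyl in place of trifluoromethyl on an aromatic carbon.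

For the measured compounds named here, three measured steps bear on this change, all among fluoro, methyl and trifluoromethyl. The third is a 1.3-fold higher number from compound 1 to compound 2 (0.11 log units; within the scatter). Together they show small movement: two steps lie within the scatter and one is only modest. None of these groups carries a ring or a carbonyl, so benzyloxycarbonyl goes beyond anything yet measured in the series, and the steps guide the expectation only loosely. No clear direction can be drawn from them, and a step beyond the scatter is not expected, although the uncertainty is wide and leans slightly towards a higher number. In this assay the expected step is a 1.1-fold higher number from compound 3 to compound 4 (0.03 log units; within the scatter). The estimate for compound 4 is 2500 nM, with an expected range from 800 nM to 8000 nM.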

Compound 4, half-maximal inhibitory concentration: 21500 nM
The estimate for compound 4 lay 8.6-fold (0.93 log units) below the measured number; measured number outside the range, above it.
By their numbers in this assay, from the lowest: compounds 1, 2 and 3 (each within the scatter of the next, the first and the last beyond it); then compound 4.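

In this assay this aromatic carbon no longer looks indifferent to its substituent: fluoro, methyl and trifluoromethyl had stayed close together, whereas benzyloxycarbonyl gives a 9.2-fold higher number from compound 3 to compound 4 (0.96 log units; beyond the scatter) as well as a 15-fold higher number from compound 2 to compound 4 (1.17 log units; beyond the scatter) and a 19-fold higher number from compound 1 to compound 4 (1.28 log units; beyond the scatter) on the weaker side of the scale. Compound 4 is therefore the weakest of the four, and its steps from compound 1 and compound 2 are the only large ones in the series, so the position has a limit on what it accepts that the three small groups did not reach. The change also brings in the first carbonyl and the first extra aromatic ring at this place, but nothing available explains the loss of activity.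

For the compounds shown here, with only one compound of this kind, the loss cannot be assigned to the ester carbonyl, the benzyl ring or the overall size of the group. From the compounds shown here alone, a methyl ester, a carboxylic acid or a primary amide on the same carbon would help to separate these, while the effect of a simple benzyl ether remains open.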